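Swapping a tert-butyl for a phenyl on a coumarin side chain

This account rests on a few compounds, and the source may have more. Where it says the series, first, only, none or still open, it means among the compounds named here.

Among the compounds with values here, in an ADME assay on A549 cells (Homo sapiens) for cytotoxicity, read by CellTiter-Glo (on this read-out higher numbers stand for lower toxicity in this test and lower numbers for higher toxicity in this test), compound 2 `Cc1c(Cc2ccc(C(C)(C)C)cc2)c(=O)oc2cc(OCC(O)CN3CCC(C(N)=O)CC3)ccc12` gives 14700 nM, the only full number measured here. Compound 1 `Cc1c(Cc2ccccc2)c(=O)oc2cc(OCC(O)CNc3cc([N+](=O)[O-])ccc3O)ccc12` reached only a limit in this assay, > 100000 nM, so it marks one of the two values sitting at the limit of > 100000 nM in this assay, at which 1 of the 2 values shown sits. Compound 3 `Cc1c(Cc2ccc(-c3ccccc3)cc2)c(=O)oc2cc(OCC(O)CN3CCC(C(N)=O)CC3)ccc12` is not yet measured; it differs from compound 2 by phenyl in place of tert-butyl on an aromatic carbon. Within the data shown here, with no measured step of this kind to lean on, the change from compound 2 to compound 3 is expected to stay within the usual scatter, as a 1.3-fold lower number from compound 2 to compound 3 (0.13 log units; within the scatter). Compound 3 is therefore expected to give about 11000 nM, between 4000 nM and 35000 nM.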

Compound 3, half-maximal cytotoxic concentration: > 100000 nM
Compound 3 gave a limit, no number; the forecaster's own chance of this, stated with the estimate: 10%; middle value at least 9.0-fold (0.95 log units) away from the limit.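

At this position, on an aromatic carbon para to a large group, the change from tert-butyl to phenyl has a clear effect in this assay: it gives an at least 6.8-fold higher number from compound 2 to compound 3 (0.83 log units; beyond the scatter). A single group at the end of this side chain can therefore move the compound from a measurable toxicity in this test to none reaching a full number. The value of compound 3 is a limit, not a number: the limit of > 100000 nM in this assay, at which 2 of the 3 values shown sit.

Still open, going by these compounds, is where a methyl, a chlorine or an amine at this position would fall relative to compound 2 and compound 3.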